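The source may report more compounds than this note shows. Statements on the series, on what has been measured and on what is new or still open speak of the compounds shown alone.

Values in a functional assay on SW982 cells (Homo sapiens) for inhibition, read by MTT assay, with a stated time of 72 h; on this read-out higher numbers stand for weaker inhibition and lower numbers for stronger inhibition:
- compound 1 `COc1cc(OC)c(OC)cc1/C=C/C(=O)c1ccc(Cl)cc1`: 58500 nM
- compound 2 `COc1cc(OC)c(OC)cc1/C=C/C(=O)c1ccccc1`: > 150000 nM (a limit)
- compound 3 `COc1cc(OC)c(OC)cc1/C=C/C(=O)c1ccc(-c2c[nH]cn2)cc1`: > 150000 nM (a limit)

Compound 2 gives > 150000 nM, which is a limit and not a number. For the measured compounds named here, the series so far shows (the limit of > 150000 nM in this assay, at which 2 of the 3 values shown sit). Only compound 1 has a true number.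

The next step leads to compound 4 `COc1cc(OC)c(OC)cc1/C=C/C(=O)c1cc(Cl)ccc1O`: 5-chloro-2-hydroxyphenyl in place of phenyl on a carbonyl carbon. The new group, 5-chloro-2-hydroxyphenyl, takes the place of phenyl on a carbonyl carbon.

The closest measured step is an at least 2.5-fold higher number from compound 1 to compound 2 (0.40 log units; beyond the scatter), where the chloro is lost. Read in reverse, it ties a chloro on the aromatic ring to the lower number. The step of an at least 2.5-fold higher number from compound 1 to compound 3 (0.40 log units; beyond the scatter) also starts from the chloro compound and ends at the limit. The remaining step, a step that the two limits leave unreadable from compound 2 to compound 3, gives no size. Going by the values given here, no measured step covers the hydroxy part of the entering group, so this part of the estimate has no direct support.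

In this assay, a move to a lower number is therefore expected, with compound 4 landing near compound 1 at 58500 nM. The expected change is an at least 3.0-fold lower number from compound 2 to compound 4 (0.47 log units; beyond the scatter). For compound 4 the estimated value is 50000 nM, with an expected range of 15000 nM to 150000 nM.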

Compound 4, half-maximal inhibitory concentration: > 150000 nM
Compound 4 was reported as a limit (the forecaster's own chance of this, stated with the estimate: 25%); middle value at least 3.0-fold (0.47 log units) away from the limit.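

In this assay compound 4 gives > 150000 nM, which is a limit and not a number. For the compounds shown here, the 5-chloro-2-hydroxyphenyl group on the carbonyl carbon still carries a chlorine, yet the change from the group in compound 1 gives an at least 2.5-fold higher number from compound 1 to compound 4 (0.40 log units; beyond the scatter), so a chlorine on this ring does not by itself bring a measured value, and compound 1 remains the only compound here with a true number. The steps between two limits, compound 2 to compound 4 among them, cannot be read, and the series now gathers at a single ceiling: the limit of > 150000 nM in this assay, at which 3 of the 4 values shown sit.

Compound 4 differs from compound 1 both in the added hydroxy and in the place of the chloro on the ring, and the compounds shown do not separate these two parts of the change. Also open, as far as these compounds go, is how a bromo, a methoxy or an amine on this same ring would read, and whether any of them improves on compound 1 at 58500 nM.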